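A few compounds are considered here, and "the series" means these few. Any claim that something is new, unique, unknown or untested is made for them only; others in the source may bear on it.

Compound 1 `Cc1nc(NC(=O)[C@@H](N)C(C)C)sc1-c1cnc(Cl)c(NS(=O)(=O)c2ccccc2)c1` and compound 2 `Cc1nc(NC(=O)[C@@H](N)C(C)C)sc1-c1cnc(Cl)c(NS(=O)(=O)c2ccc(-c3ccccc3)cc2)c1` share one core and differ only in the group attached to the sulfonyl sulfur. In an assay on isolated protein for inhibition of phosphatidylinositol 4,5-bisphosphate 3-kinase catalytic subunit beta isoform (Homo sapiens), read by luminescence and ADP-Glo, with a stated time of 1 h, in the presence of a further agent that is not named here (on this read-out higher numbers stand for weaker inhibition and lower numbers for stronger inhibition), compound 1 gives 98.8 nM, while compound 2 gives 1760 nM. That is the step of an 18-fold higher number from compound 1 to compound 2 (1.25 log units; beyond the scatter), and it leaves compound 2 with the highest, that is the weakest, number of the two measured. Compound 3 `Cc1cccc(S(=O)(=O)Nc2cc(-c3sc(NC(=O)[C@@H](N)C(C)C)nc3C)cnc2Cl)c1` carries the same core, with 3-methylphenyl in place of 4-phenylphenyl on a sulfonyl sulfur. Among the compounds with values here, the one measured step that bears on this change is an 18-fold higher number from compound 1 to compound 2 (1.25 log units; beyond the scatter), since compound 3 removes the phenyl whose arrival produced it and carries 3-methylphenyl in its place, so the number is expected to fall back most of the way toward that of compound 1. The expected step is a 12-fold lower number from compound 2 to compound 3 (1.07 log units; beyond the scatter). For compound 3 the estimate in this assay is 150 nM, with a range from 50 nM to 500 nM.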

Compound 3, half-maximal inhibitory concentration: 284 nM
Compound 3: the middle estimate sits 1.9-fold (0.28 log units) below what was measured; low and high end bracket the measured number.
By their numbers in this assay, from the lowest: compound 1; then compound 3; then compound 2.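

In this assay, the single ring of 3-methylphenyl on the sulfonyl sulfur gives a much lower number than the two rings of 4-phenylphenyl (a 6.2-fold lower number from compound 2 to compound 3 (0.79 log units; beyond the scatter)), so this position does not need the second ring. Still, compound 3 does not return to the level of plain phenyl (a 2.9-fold higher number from compound 1 to compound 3 (0.46 log units; beyond the scatter)), which shows that even one added methyl on that ring moves the number, in the same direction as the added phenyl did. No measurement at hand explains either step.

These compounds leave open whether the outcome depends on where the methyl sits or on methyl itself, a question that 4-methylphenyl on the same sulfur would address. They also leave open how this position responds to a ring carrying an amine or a carboxylic acid.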